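Trading 2-Nitrophenyl for Furan-2-yl in Compound 4

A few compounds are considered here, and "the series" means these few. Any claim that something is new, unique, unknown or untested is made for them only; others in the source may bear on it.

The measured compounds:
compound 1, `O=C1N=C(C2C(=O)c3ccccc3C2=O)CC(c2ccccc2[N+](=O)[O-])N1`, which gives 30% in a functional assay on the whole organism for inhibition, with Rattus norvegicus as the target, read by paw edema, with stated times of 30 min and 2 h, at a dose of 10 mg/kg by the oral route; on this read-out lower numbers stand for less inhibition and higher numbers for more inhibition at the one dose given (going by the name of the read-out);
compound 2, `O=C1N=C(C2C(=O)c3ccccc3C2=O)CC(c2ccccc2)N1`, which gives 33%;
compound 3, `CN(C)c1ccc(C2CC(C3C(=O)c4ccccc4C3=O)=NC(=O)N2)cc1`, which gives 29%.

Among these three numbers in this assay, compound 1 stands second highest. The nearest number to it is shown by a number 1 percentage points lower from compound 1 to compound 3 (within the scatter), and the furthest by a number 3 percentage points higher from compound 1 to compound 2 (within the scatter). The remaining pair behaves the same way: a number 4 percentage points lower from compound 2 to compound 3 (within the scatter). None of the three steps reaches beyond the scatter, so the three compounds cannot be ranked against one another on these data.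

Compound 4, `O=C1N=C(C2C(=O)c3ccccc3C2=O)CC(c2ccco2)N1`, has not yet been measured in this assay. It differs from compound 1 in one place: furan-2-yl in place of 2-nitrophenyl on a saturated ring carbon. Going by the values given here, the step that bears most directly on this change is the one in which the group on the same saturated ring carbon was exchanged, namely a number 1 percentage points lower from compound 1 to compound 3 (within the scatter); the exchange of nitro for hydrogen on the aromatic carbon, a number 3 percentage points higher from compound 1 to compound 2 (within the scatter), is a second point of comparison. Because a number 1 percentage points lower from compound 1 to compound 3 (within the scatter) stayed within the scatter, and because a number 3 percentage points higher from compound 1 to compound 2 (within the scatter) did likewise, no step beyond the scatter is expected for compound 4 in either direction. Compound 4 is expected to show no change at the digits printed from compound 1 to compound 4 (within the scatter). The estimate for compound 4 in this assay is 30%, with a range from 18% to 42%.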

Compound 4, a percentage reported as inhibition, in the whole organism at one dose (the size of the read-out at that dose, not a potency): 25%
Beside the measured number, compound 4's estimate is 5 percentage points above it; the measured number falls inside the stated range.
By their numbers in this assay, from the lowest: compounds 4, 3, 1 and 2 (each within the scatter of the next).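

The earlier steps shown here at this saturated ring carbon only exchanged one six-membered aromatic ring of carbon for another, whereas compound 4 places a five-membered aromatic ring with 1 hetero atom there. In this assay this change gives a number 5 percentage points lower from compound 1 to compound 4 (within the scatter), while the same comparison with the other two compounds gives a number 4 percentage points lower from compound 3 to compound 4 (within the scatter) and a number 8 percentage points lower from compound 2 to compound 4 (within the scatter). The position therefore accepts furan-2-yl, with its smaller heavy-atom count, in place of each of the three earlier aromatic groups without any step leaving the scatter, and nothing available explains the numbers.

From the compounds shown here alone, all four compounds keep the shared core and an aromatic ring at this carbon, so it remains open whether a saturated ring such as cyclohexyl or an open chain such as n-butyl would take the number beyond the scatter. Going by these compounds, it is also open whether a carboxylic acid or a primary amine on the aromatic ring would do so, and whether any group here would separate these compounds at another dose.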